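Working notes: aryl swap on the shared core

The source may report more compounds than this note shows. Statements on the series, on what has been measured and on what is new or still open speak of the compounds shown alone.

Measured in a functional assay on PC-3 cells (Homo sapiens) for inhibition, read by MTT assay, with a stated time of 72 h; on this read-out higher numbers stand for weaker inhibition and lower numbers for stronger inhibition:
- compound 1 `CC(C)n1ncc2c(C(=O)NCc3ccccc3)cccc21`: 15200 nM
- compound 2 `Cc1ccc(-n2cc(CNC(=O)c3cccc4c3cnn4C(C)C)nn2)cc1C`: 23400 nM

Compound 2 gives the highest of the two numbers, but compound 1 sits within the scatter of it, so no order between the two can be drawn. Compound 3 `CC(C)n1ncc2c(C(=O)NCc3cn(-c4ccc([N+](=O)[O-])cc4)nn3)cccc21` differs from compound 2 by 4-nitrophenyl in place of 3,4-dimethylphenyl on an aromatic nitrogen. Within the data shown here, no step between measured compounds is available for this kind of change, and both measured values are weak. In this assay the expected step is a 1.2-fold lower number from compound 2 to compound 3 (0.07 log units; within the scatter), that is, nothing beyond the scatter. Compound 3 is estimated at 20000 nM, with a range from 7000 nM to 55000 nM.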

Compound 3, half-maximal inhibitory concentration: > 40000 nM
Compound 3: only a limit was reported; the forecaster's own chance of this, stated with the estimate: 15%; middle value at least 2.0-fold (0.30 log units) away from the limit.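

Among these compounds, this is the first step at the aromatic nitrogen of the triazole-bearing side chain: 4-nitrophenyl in place of 3,4-dimethylphenyl in this assay gives an at least 1.7-fold higher number from compound 2 to compound 3 (0.23 log units; that floor lies within the scatter). Compound 3 carries only a limit of the assay, not a number: the limit of > 40000 nM in this assay, at which 1 of the 3 values shown sits. The change therefore shows no sign of stronger inhibition, but its true size cannot be read, since the floor of the step stays within the scatter.

Open, going by these compounds, is whether a 4-aminophenyl or 4-carboxyphenyl group on the same nitrogen would move the number beyond the scatter of compound 2.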